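Working notes: from compound 2 to compound 3

The source may report more compounds than this note shows. Statements on the series, on what has been measured and on what is new or still open speak of the compounds shown alone.

Values measured so far in an ADME assay on HEK293 cells (Homo sapiens) for cytotoxicity, read by CellTiter-Glo and resazurin assay, with a stated time of 72 h (on this read-out lower numbers stand for an effect already at smaller amounts and higher numbers for an effect only at larger amounts of compound), are:
- compound 1 `CCOC(=O)CCCCCOc1cccc(CN(C(=O)c2ccccc2)C(C)C)c1` gives > 26000 nM as a limit
- compound 2 `CCOC(=O)CCCCCOc1cccc(CN(C(=O)c2ccc(-c3cccc(OC(F)(F)F)c3)cc2)C(C)C)c1` gives > 26000 nM as a limit

Compound 2 stands at > 26000 nM in this assay and this is a limit of the assay, not a number. Compound 3 `CCOC(=O)CCCCCOc1cccc(CN(C(=O)c2ccc(-c3cccc(F)c3)cc2)C(C)C)c1` differs from compound 2 by fluoro in place of trifluoromethoxy on an aromatic carbon in the form of fluoro in place of trifluoromethoxy on an aromatic carbon, meta to a large group. Within the data shown here, the only measured step bearing on this change is a step that the two limits leave unreadable from compound 1 to compound 2 for 3-(trifluoromethoxy)phenyl in place of hydrogen on an aromatic carbon, so it offers no size to carry over. Because of the limit of > 26000 nM in this assay, at which 2 of the 2 values shown sit, for compound 1 and compound 2 alike, no step beyond the scatter is expected in this assay and a further limit is the likeliest report. The step expected is a number no higher from compound 2 to compound 3 (the limit leaves the size open) with no direction favoured. For compound 3 the estimate is 26000 nM with an expected range from 13000 nM to 52000 nM on this read-out.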

Compound 3, half-maximal effective concentration: > 26000 nM
Compound 3: a limit, no number; the forecaster's own chance of this, stated with the estimate: 90%; the middle value sits exactly at the limit.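

In this assay compound 3 gives > 26000 nM as a limit of the assay, not a number. Among these compounds, no step among compound 1, compound 2 and compound 3 can be read, as all three values are limits: the limit of > 26000 nM in this assay, at which 3 of the 3 values shown sit. The compounds shown leave open whether the 3-fluorophenyl and 3-(trifluoromethoxy)phenyl groups differ at all on this read-out.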